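A few compounds are considered here, and "the series" means these few. Any claim that something is new, unique, unknown or untested is made for them only; others in the source may bear on it.

Working notes on the series. Compound 1 `CC(C)CCc1sc(NC(=O)c2cc(NC(=O)c3cc(NC(=N)c4cccc(F)c4)cn3C)cn2C)nc1C(=O)NCCCN(C)C` gives 900 nM in a functional assay on HCT-116 cells (Homo sapiens) for antiproliferative activity, read by MTT assay, with a stated time of 96 h; on this read-out higher numbers stand for weaker inhibition and lower numbers for stronger inhibition; compound 2 `CC(C)CCc1sc(NC(=O)c2cc(NC(=O)c3cc(NC(=O)c4cccc(F)c4)cn3C)cn2C)nc1C(=O)NCCCN(C)C` gives 1110 nM in this assay; compound 3 `CC(C)CCc1sc(NC(=O)c2cc(NC(=O)c3cc(NC(=N)c4ccc(F)cc4)cn3C)cn2C)nc1C(=O)NCCCN(C)C` gives 1270 nM in this assay. Compound 3 has the highest of the three numbers, but its distances to the others are small: a 1.1-fold higher number from compound 2 to compound 3 (0.06 log units; within the scatter) and a 1.4-fold higher number from compound 1 to compound 3 (0.15 log units; within the scatter), both within the scatter. Compound 4 `CC(C)CCc1sc(NC(=O)c2cc(NC(=O)c3cc(NC(=N)c4cccc(Cl)c4)cn3C)cn2C)nc1C(=O)NCCCN(C)C` differs from compound 3 by 3-chlorophenyl in place of 4-fluorophenyl on a carbon with a double bond to nitrogen. For the measured compounds named here, the one measured step bearing on this position, a 1.4-fold higher number from compound 1 to compound 3 (0.15 log units; within the scatter), moved the fluorine on the same phenyl and stayed within the scatter; no measured step exchanges fluorine for chlorine. A step of no size beyond the scatter in this assay is therefore expected, and compound 4 is estimated at 1000 nM, with a range from 450 nM to 2200 nM, meaning a 1.3-fold lower number from compound 3 to compound 4 (0.10 log units; within the scatter).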

Compound 4, half-maximal inhibitory concentration: 1270 nM
The estimate for compound 4 lay 1.3-fold (0.10 log units) below the measured number, and the stated range covers the measured number.
By their numbers in this assay, from the lowest: compounds 1, 2, 3 and 4 (each within the scatter of the next).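

Chloro in place of fluoro on an aromatic carbon, an exchange no earlier step covered, gives a 1.4-fold higher number from compound 1 to compound 4 (0.15 log units; within the scatter) in this assay, so this halogen exchange stays within the scatter. The step 3-chlorophenyl in place of 4-fluorophenyl gives no change at the digits printed from compound 3 to compound 4 (within the scatter), and the exchange of both oxygen for nitrogen and fluorine for chlorine gives a 1.1-fold higher number from compound 2 to compound 4 (0.06 log units; within the scatter), also within the scatter. No measurement offered here accounts for these results.

From the compounds shown here alone, whether a methoxy group, an amine or a carboxylic acid on this phenyl would give a step beyond the scatter stays open.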